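Aromatic ring replaces saturated ring in a dihydropyridine side chain

The source may hold more compounds than are shown below. What is called first, only, known or untested is meant among the compounds shown, and "the series" means these compounds.

Compound 3, `CCO/C(O)=C1\C(COCCN2CC(=O)N=C2N)=NC(C)=C(C(=O)OC)C1c1ccccc1Cl`, gives 20 nM in a functional assay (aorta) with Rattus norvegicus as the target (a higher number here means a weaker inhibitor, a lower number a stronger inhibitor), the lowest of the three numbers shown, though compound 2 (`CCO/C(O)=C1\C(COCCN2C(=O)CNC2=O)=NC(C)=C(C(=O)OC)C1c1ccccc1Cl`, 31.6 nM) lies within the scatter of it. Compound 1, `CCOC(=O)c1cnnn1CCOCC1=NC(C)=C(C(=O)OC)C(c2ccccc2Cl)/C1=C(\O)OCC`, gives 100 nM. Compound 4, `CCO/C(O)=C1\C(COCCn2cc(N)n(C)c2=O)=NC(C)=C(C(=O)OC)C1c1ccccc1Cl`, carries a group of 8 heavy atoms (4 carbon, 3 nitrogen, 1 oxygen; one five-membered aromatic ring with 2 hetero atoms) in place of a group of 7 heavy atoms (3 carbon, 3 nitrogen, 1 oxygen; one five-membered non-aromatic ring with 2 hetero atoms), on a saturated chain carbon, two bonds along the chain from an oxygen on a saturated carbon. The step that bears on this is a 5.0-fold lower number from compound 1 to compound 3 (0.70 log units; beyond the scatter), where a five-membered aromatic ring gave way to a non-aromatic one; compound 4 reverses that direction of change, but with a different aromatic ring carrying a hydrogen-bond donor. The step of a 1.6-fold lower number from compound 2 to compound 3 (0.20 log units; within the scatter) shows that swapping one non-aromatic ring for another changed little. A modest weakening or no step beyond the scatter is therefore expected, and compound 4 is estimated at 32 nM (range 12 nM to 85 nM), a step of a 1.6-fold higher number from compound 3 to compound 4 (0.20 log units; within the scatter).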

Compound 4, half-maximal inhibitory concentration: 25.1 nM
For compound 4 the middle estimate is 1.3-fold (0.11 log units) above the measured one; low and high end bracket the measured number.
By their numbers in this assay, from the lowest: compounds 3, 4 and 2 (each within the scatter of the next); then compound 1.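

In this assay an aromatic ring at this place on the saturated chain carbon sits level with the non-aromatic rings, with a 1.3-fold higher number from compound 3 to compound 4 (0.10 log units; within the scatter) and a 1.3-fold lower number from compound 2 to compound 4 (0.10 log units; within the scatter). The drop from compound 1 persists, with a 4.0-fold lower number from compound 1 to compound 4 (0.60 log units; beyond the scatter), so having an aromatic ring does not by itself set compound 1 apart from the others. Nothing measured here explains these steps. On these data alone, whether an open-chain amine, a carboxylic acid or a longer chain before the ring would keep the number this low remains open.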